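Working notes on compound 4: bromo in place of nitro

A few compounds are considered here, and "the series" means these few. Any claim that something is new, unique, unknown or untested is made for them only; others in the source may bear on it.

Measured so far:
compound 1 `O=[N+]([O-])c1cccc(CSc2nnc(-c3ccc4c(c3)OCCO4)n2-c2ccccc2)c1` gives 7590 nM
compound 2 `Clc1cccc(CSc2nnc(-c3ccc4c(c3)OCCO4)n2-c2ccccc2)c1` gives 10600 nM
compound 3 `Cc1ccccc1CSc1nnc(-c2ccc3c(c2)OCCO3)n1-c1ccccc1` gives 12700 nM

All three share one core and differ only in the aryl group carried on the saturated chain carbon bound to a sulfur. In a functional assay on SW 1116 cells (Homo sapiens) for antiproliferative activity, read by MTT assay, with a stated time of 24 h (a lower number here means a stronger inhibitor, a higher number a weaker inhibitor), compound 1 has the lowest of the three numbers, but the steps of a 1.4-fold higher number from compound 1 to compound 2 (0.15 log units; within the scatter) and a 1.7-fold higher number from compound 1 to compound 3 (0.22 log units; within the scatter) both stay within the scatter, as does a 1.2-fold higher number from compound 2 to compound 3 (0.08 log units; within the scatter), so none of the three can be set apart from the others on these data.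

Compound 4 `Brc1cccc(CSc2nnc(-c3ccc4c(c3)OCCO4)n2-c2ccccc2)c1` is not yet measured. Relative to compound 1 the change is bromo in place of nitro on an aromatic carbon. The step that bears most directly on it is a 1.4-fold higher number from compound 1 to compound 2 (0.15 log units; within the scatter). That step also exchanges the nitro for a halogen and moved the number only within the scatter. The steps of a 1.7-fold higher number from compound 1 to compound 3 (0.22 log units; within the scatter) and a 1.2-fold higher number from compound 2 to compound 3 (0.08 log units; within the scatter) exchange the whole aryl group and add little beyond confirming that this assay has so far been flat across the series. The expected step is therefore a 1.3-fold higher number from compound 1 to compound 4 (0.10 log units; within the scatter), with no movement beyond the scatter and, if anything, a slightly higher number. Compound 4 is estimated at 9500 nM, with a range of 5000 nM to 18000 nM.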

Compound 4, half-maximal inhibitory concentration: 26200 nM
Compound 4: the middle estimate sits 2.8-fold (0.44 log units) below what was measured; the measured number lies above the stated range.
By their numbers in this assay, from the lowest: compounds 1, 2 and 3 (each within the scatter of the next); then compound 4.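

In this assay, within the data shown here, this aromatic carbon proves less tolerant than the earlier compounds suggested: chloro in place of nitro stayed within the scatter (a 1.4-fold higher number from compound 1 to compound 2 (0.15 log units; within the scatter)), whereas bromo in place of nitro goes beyond it (a 3.5-fold higher number from compound 1 to compound 4 (0.54 log units; beyond the scatter)). The two halogens are not interchangeable here, as the exchange of chloro for bromo alone, a change of a single atom, also goes beyond the scatter (a 2.5-fold higher number from compound 2 to compound 4 (0.39 log units; beyond the scatter)). Among these compounds, compound 4 also separates from the 2-methylphenyl compound (a 2.1-fold higher number from compound 3 to compound 4 (0.31 log units; beyond the scatter)), which makes it the weakest of the four and the first compound set apart from all the others, and nothing measured here accounts for the separation.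

The compounds shown leave open how fluoro, iodo, an amine or a carboxylic acid on this aromatic carbon would read in this assay. Going by these compounds, with a single bromo compound and a single chloro compound, it also stays open whether the higher number follows a trend across the halogens or is particular to bromo.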